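Adding a chloro group to compound 3

The compounds below may be only part of what the source reports. "The series", "measured", "known", "first", "only" and "open" are said of these compounds alone.

Measured in an ADME assay on BHK-21 cells (Mesocricetus auratus) for cytotoxicity, read by MTT assay; on this read-out lower numbers stand for higher toxicity in this test and higher numbers for lower toxicity in this test:
- Compound 1 `CC(=O)c1ccc2[nH]c(-c3ccccc3)nc2c1`: > 100000 nM
- Compound 2 `CC(=O)c1ccc2[nH]c(-c3ccc(Cl)cc3)nc2c1`: > 100000 nM
- Compound 3 `CC(=O)c1ccc2c(c1)nc(-c1ccccc1)n2C1CCCCC1`: 100000 nM

The entry of compound 1 is a limit, not a number. The entry for compound 2 is also a limit. Compound 3 alone has an actual number, 100000 nM. The other two sit at the limit of > 100000 nM in this assay, at which 2 of the 3 values shown sit.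

Compound 4 `CC(=O)c1ccc2c(c1)nc(-c1ccc(Cl)cc1)n2C1CCCCC1` differs from compound 3 by chloro in place of hydrogen on an aromatic carbon.

The same exchange gave a step that the two limits leave unreadable from compound 1 to compound 2. Adding cyclohexyl gave a number no higher from compound 1 to compound 3 (the limit leaves the size open). Neither step has a readable size, so no shift in this assay is expected beyond the usual scatter. The expected change is no change at the digits printed from compound 3 to compound 4 (within the scatter). For compound 4 the estimated value is 100000 nM, with an expected range from 50000 nM to 200000 nM.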

Compound 4, half-maximal cytotoxic concentration: > 100000 nM
Compound 4: a limit, no number (the forecaster's own chance of this, stated with the estimate: 55%); the middle value sits exactly at the limit.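

In this assay, going by these compounds alone, the chloro exchange gives a number no lower from compound 3 to compound 4 (the limit leaves the size open) and so shows a direction for the first time, though no size. Compound 4 gives > 100000 nM, which is a limit and not a number. The other steps cannot be read either, and no size can be given for any step because the values gather at one limit: the limit of > 100000 nM in this assay, at which 3 of the 4 values shown sit.

Still open, going by these compounds, is whether a different group on this aromatic carbon, such as an amine or a carboxylic acid, would give a clearly lower number in this assay.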